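A few compounds are considered here, and "the series" means these few. Any claim that something is new, unique, unknown or untested is made for them only; others in the source may bear on it.

Measured so far:
- compound 1, `COc1cc(-c2nn(-c3cccc(NC(=O)c4cccc(C(F)(F)F)c4)c3)cc2-c2ccncc2)ccc1Cl`: 811 nM
- compound 2, `COc1cc(-c2nn(-c3cccc(NC(=O)Nc4ccc(Cl)c(Cl)c4)c3)cc2-c2ccncc2)ccc1Cl`: 859 nM

Both numbers come from a functional assay on RXF 393 cells (Homo sapiens) for inhibition, read by sulforhodamine B assay, with a stated time of 48 h; a higher number here means a weaker inhibitor of growth, a lower number a stronger inhibitor of growth. Compound 2 has the highest of the two numbers, with compound 1 nearest; the two values lie within the scatter of one another, so neither can be called the stronger inhibitor.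

Compound 3, `COc1cc(-c2nn(-c3cccc(NC(=O)Nc4cccc(C(F)(F)F)c4)c3)cc2-c2ccncc2)ccc1Cl`, has not yet been measured. It differs from compound 2 in one place: 3-(trifluoromethyl)phenyl in place of 3,4-dichlorophenyl on an amide-type nitrogen. Going by the values given here, the only measured step, a 1.1-fold higher number from compound 1 to compound 2 (0.02 log units; within the scatter), changed both the carbonyl substituent and the type of linkage at once and stayed within the scatter, so it bears only loosely on the present change and suggests little movement. Among the compounds with values here, no step isolates the swap of aryl groups on the urea nitrogen, so the expectation rests on the closeness of compound 1 and compound 2.

Compound 3 is therefore expected to give 850 nM in this assay, within a range of 350 nM to 2100 nM, which means an expected step of a 1.0-fold lower number from compound 2 to compound 3 (0.00 log units; within the scatter) that is not beyond the scatter.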

Compound 3, concentration for 50% growth inhibition: 777 nM
Estimate against measurement, compound 3: 1.1-fold (0.04 log units) above; low and high end bracket the measured number.
By their numbers in this assay, from the lowest: compounds 3, 1 and 2 (each within the scatter of the next).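

Within this assay, exchanging 3,4-dichlorophenyl for 3-(trifluoromethyl)phenyl on the amide-type nitrogen gives a 1.1-fold lower number from compound 2 to compound 3 (0.04 log units; within the scatter) and so has no readable effect, even though the two groups differ in their atoms and size. With 3-(trifluoromethyl)phenyl held fixed, compound 3 also separates the linker from the aryl group, which the step between compound 1 and compound 2 could not do: placing (3-(trifluoromethyl)phenyl)amino on the carbonyl carbon gives a 1.0-fold lower number from compound 1 to compound 3 (0.02 log units; within the scatter) and also has no readable effect. No supporting measurement is available to explain these small steps.

Going by these compounds, it remains open whether the number would stay put with an amine or a carboxylic acid on that ring, or with a longer alkyl chain replacing the ring. On these data alone, the shared core is identical in all three compounds, so its role remains untested.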